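Cytotoxicity notes: aryl-amine substituents on the salicylanilide series

The source may report more compounds than this note shows. Statements on the series, on what has been measured and on what is new or still open speak of the compounds shown alone.

The series shares a salicylanilide-type core, seen in compound 1 `CC(=O)Nc1ccc(NC(=O)c2cc(Cl)ccc2O)c(Cl)c1`, for which an ADME assay on A549 cells (Homo sapiens) for cytotoxicity, read by resazurin assay, with a stated time of 48 h (on this read-out higher numbers stand for lower toxicity in this test and lower numbers for higher toxicity in this test), reports "not determined" (no result reported). Compound 2 `CCCCCCC(C)Nc1ccc(NC(=O)c2cc(Cl)ccc2O)c(Cl)c1` gives 23500 nM in this assay, the higher of the two numbers recorded; compound 3 `O=C(Nc1ccc(NCc2ccccc2)cc1Cl)c1cc(Cl)ccc1O` gives 19700 nM, and the step of a 1.2-fold lower number from compound 2 to compound 3 (0.08 log units; within the scatter) is within the scatter. Compound 4 `O=C(Nc1ccc(NCc2ccc(O)cc2)cc1Cl)c1cc(Cl)ccc1O` is not yet measured. Its change from compound 2 is 4-hydroxybenzyl in place of 1-methylheptyl on a nitrogen on an aromatic ring. Within the data shown here, the only step bearing on it, benzyl in place of 1-methylheptyl at the same nitrogen, a 1.2-fold lower number from compound 2 to compound 3 (0.08 log units; within the scatter), moved nothing beyond the scatter, so no step beyond the scatter is expected for compound 4 either: a 1.2-fold lower number from compound 2 to compound 4 (0.07 log units; within the scatter). Compound 4 is therefore estimated at 20000 nM, in the range 8000 nM to 50000 nM.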

Compound 4, half-maximal cytotoxic concentration: 116000 nM
Estimate against measurement, compound 4: 5.8-fold (0.76 log units) below, outside the stated range (above it).
By their numbers in this assay, from the lowest: compounds 3 and 2 (each within the scatter of the next); then compound 4.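

In this assay the nitrogen substituent turns out to matter: hydroxy in place of hydrogen on an aromatic carbon gives a 5.9-fold higher number from compound 3 to compound 4 (0.77 log units; beyond the scatter) and marks lower toxicity in this test, which the plain benzyl change did not. Against the open chain, 4-hydroxybenzyl gives a 4.9-fold higher number from compound 2 to compound 4 (0.69 log units; beyond the scatter) and so the shift appears only with the hydroxy present. Nothing available explains this shift.

As far as these compounds go, whether the effect is specific to hydroxy remains open, since a methoxy or an amine on the same ring could separate the two readings. From the compounds shown here alone, whether a hydroxy on the 1-methylheptyl chain would act alike is also open.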